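The source may report more compounds than this note shows. Statements on the series, on what has been measured and on what is new or still open speak of the compounds shown alone.

Compound 1: `CC(C)[C@H](NC(=O)COc1cccc2ccccc12)C(=O)N[C@@H](CC(=O)O)C(=O)COc1cc(C(F)(F)F)n(C)n1`. In a functional assay on Jurkat cells (Homo sapiens) for inhibition (on this read-out higher numbers stand for weaker inhibition and lower numbers for stronger inhibition), compound 1 gives 46000 nM.
Compound 2: `Cc1cc(OCC(=O)[C@H](CC(=O)O)NC(=O)[C@@H](NC(=O)COc2cccc3ccccc23)C(C)C)nc(C)n1`. In this assay compound 2 shows only a limit, > 200000 nM.
Compound 3: `CC(C)[C@H](NC(=O)COc1cccc2ccccc12)C(=O)N[C@@H](CC(=O)O)C(=O)COc1ccc2ccccc2n1`. In this assay compound 3 likewise shows only a limit, > 200000 nM.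

Compound 3 therefore stands at the edge of what this assay can report; the limit of > 200000 nM in this assay, at which 2 of the 3 values shown sit, applies to it and to compound 2 alike, so no number separates them, and the step that the two limits leave unreadable from compound 2 to compound 3 cannot be sized. Against compound 1, the step of an at least 4.3-fold higher number from compound 1 to compound 3 (0.63 log units; beyond the scatter) and the step of an at least 4.3-fold higher number from compound 1 to compound 2 (0.63 log units; beyond the scatter) both go towards weaker inhibition.

Compound 4, `CC(C)[C@H](NC(=O)COc1cccc2ccccc12)C(=O)N[C@@H](CC(=O)O)C(=O)COc1ncnc2ccccc12`, is not yet measured. It differs from compound 3 by quinazolin-4-yl in place of quinolin-2-yl on an oxygen on a saturated carbon. Among the measured compounds shown here, no measured step swaps one such bicyclic group for another with a readable size; the only related step, a step that the two limits leave unreadable from compound 2 to compound 3, stays unreadable. The expectation for compound 4 is thus a step of a number no higher from compound 3 to compound 4 (the limit leaves the size open), most likely again a limit rather than a number. Compound 4 is estimated at 200000 nM, with a range from 60000 nM to 700000 nM.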

Compound 4, half-maximal inhibitory concentration: > 200000 nM
Compound 4: a limit, no number; the forecaster's own chance of this, stated with the estimate: 70%; the middle value lies on the limit itself.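

Placing quinazolin-4-yl on this oxygen, with 2 ring nitrogens where quinolin-2-yl has 1, gives no readable value in this assay: compound 4 shows only a limit, > 200000 nM. The one readable step is an at least 4.3-fold higher number from compound 1 to compound 4 (0.63 log units; beyond the scatter), so a third replacement of 1-methyl-5-(trifluoromethyl)-1H-pyrazol-3-yl also goes towards weaker inhibition, and among the compounds shown only compound 1 gives a number. The steps among compound 2, compound 3 and compound 4 cannot be read, and the values now gather at one end of the range: the limit of > 200000 nM in this assay, at which 3 of the 4 values shown sit.

From the compounds shown here alone, how far these three groups differ from one another stays open. Also open, going by these compounds, is which part of the 1-methyl-5-(trifluoromethyl)-1H-pyrazol-3-yl group matters, for instance whether a 1-methyl-1H-pyrazol-3-yl group without the trifluoromethyl, or a plain phenyl ring, would still give a number.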